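This account rests on a few compounds, and the source may have more. Where it says the series, first, only, none or still open, it means among the compounds named here.

Measured compounds:
- compound 1, `CC1=CC[C@H](C(C)(C)NC(=S)N/N=C/c2ccccc2)CC1`: in an ADME assay on Vero cells (Chlorocebus sabaeus) for inhibition, read by sulforhodamine B assay, with a stated time of 48 h (on this read-out lower numbers stand for stronger inhibition of growth and higher numbers for weaker inhibition of growth), compound 1 gives 20500 nM
- compound 2, `COc1ccc(/C=N/NC(=S)NC(C)(C)[C@H]2CC=C(C)CC2)cc1`: in this assay compound 2 gives 12200 nM
- compound 3, `CC1=CC[C@H](C(C)(C)NC(=S)N/N=C/c2ccc(O)cc2)CC1`: in this assay compound 3 gives only a limit, > 100000 nM

The value of compound 3 is a limit of the assay, not a number; this is the limit of > 100000 nM in this assay, at which 1 of the 3 values shown sits.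

Compound 2 differs from compound 1 by methoxy in place of hydrogen on an aromatic carbon. That change made the step of a 1.7-fold lower number from compound 1 to compound 2 (0.23 log units; within the scatter), which is within the scatter. Compound 3 differs from compound 1 by hydroxy in place of hydrogen on an aromatic carbon, so the core of compound 3 carries a hydroxy group that the core of compound 1 lacks. The step from compound 1 to compound 3 was an at least 4.8-fold higher number from compound 1 to compound 3 (0.68 log units; beyond the scatter), and from compound 2 to compound 3 it was an at least 8.1-fold higher number from compound 2 to compound 3 (0.91 log units; beyond the scatter).

Compound 4, `COc1cc(/C=N/NC(=S)NC(C)(C)[C@H]2CC=C(C)CC2)ccc1O`, has not yet been measured in this assay. It differs from compound 3 by methoxy in place of hydrogen on an aromatic carbon. Among the measured compounds shown here, this is the same kind of change as the one from compound 1 to compound 2, but not the same: there the methoxy entered para to a large group, whereas here it enters ortho to a hydroxy group and meta to a large group.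

Since the earlier step was within the scatter, the step from compound 3 to compound 4 is expected to be small as well, a number no higher from compound 3 to compound 4 (the limit leaves the size open), though with a limit as its starting point the outcome is uncertain. Compound 4 is therefore estimated at 100000 nM in this assay, expected to fall between 40000 nM and 300000 nM, and it may well again be reported only as a limit.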

Compound 4, concentration for 50% growth inhibition: 19700 nM
Estimate against measurement, compound 4: 5.1-fold (0.71 log units) above; the measured number lies below the stated range.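

In this assay, putting methoxy in place of hydrogen on an aromatic carbon of compound 3 gave an at least 5.0-fold lower number from compound 3 to compound 4 (0.70 log units; beyond the scatter), so on this core the change moved the number by more than the usual scatter. The same change therefore did not carry over at the same size from one core to the other: the same change on two cores in this assay, a 1.7-fold lower number (0.23 log units; within the scatter) from compound 1 to compound 2 and an at least 5.0-fold lower number (0.70 log units; beyond the scatter) from compound 3 to compound 4, at least 3.0-fold (0.48 log units) apart, beyond the scatter of two such steps. This does not show why the two steps differ, since the core of compound 3 carries a hydroxy group and the methoxy of compound 4 enters ortho to that hydroxy group and meta to a large group, while the methoxy of compound 2 sits para to a large group, so core and place change together, and the true size of the newer step also stays unknown: the limit of > 100000 nM in this assay, at which 1 of the 4 values shown sits.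

The compounds shown leave open whether methoxy placed ortho to a hydroxy group and meta to a large group would give a similar step without the hydroxy group being present, which would help separate the effect of place from that of core. They also leave open how other groups at these ring positions, such as an amine or a carboxylic acid, would behave on either core.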